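A few compounds are considered here, and "the series" means these few. Any claim that something is new, unique, unknown or untested is made for them only; others in the source may bear on it.

Within the data shown here, only two compounds sharing this core have been tested in a functional assay on HeLa cells (Homo sapiens) for cytotoxicity, read by MTT assay, with a stated time of 24 h; a lower number here means a stronger inhibitor, a higher number a weaker inhibitor. In that assay compound 1 `Nc1cccn2cc(Cc3ccccc3)c(=O)nc12` gives 112000 nM and compound 2 `O=c1nc2ccc(Br)cn2cc1Cc1ccccc1` gives 152000 nM. These two numbers lie within the scatter of each other, so compound 2 stands level with compound 1. Compound 3 `Nc1cc(Br)cn2cc(Cc3ccccc3)c(=O)nc12` departs from compound 2 in one place: amino in place of hydrogen on an aromatic carbon, with amino in place of hydrogen on an aromatic carbon. It therefore keeps the bromo group of compound 2 and also carries the amino group found in compound 1. Among the measured compounds shown here, no measured pair isolates this change. Compound 1, which has the amino group without the bromo group, gives 112000 nM, so no shift beyond the scatter is expected in this assay. The expected change is a 1.3-fold lower number from compound 2 to compound 3 (0.10 log units; within the scatter). For compound 3 the estimated value is 120000 nM, with an expected range from 55000 nM to 250000 nM.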

Compound 3, half-maximal inhibitory concentration: > 1000000 nM
Compound 3 ended at the assay's limit (the forecaster's own chance of this, stated with the estimate: 10%); at least 8.3-fold (0.92 log units) between middle value and limit.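

Compound 3 stands at a limit of this assay, not at a number: the limit of > 1000000 nM in this assay, at which 1 of the 3 values shown sits.

Amino in place of hydrogen on this aromatic carbon, ortho to a fused ring and two atoms from the ring nitrogen, gives an at least 6.5-fold higher number from compound 2 to compound 3 (0.81 log units; beyond the scatter), while bromo in place of hydrogen on the compound carrying the amino group gives an at least 8.9-fold higher number from compound 1 to compound 3 (0.95 log units; beyond the scatter). Compound 1 and compound 2 stand level with each other, so the amino and bromo groups together read differently from either group alone, which those two compounds could not show.

The compounds shown leave open how the core without either group reads in this assay. They also leave open whether a methyl or hydroxyl group on this aromatic carbon, or chloro in place of bromo, would give the same step.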